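Replacing the piperidinyl group with an open chain

A few compounds are considered here, and "the series" means these few. Any claim that something is new, unique, unknown or untested is made for them only; others in the source may bear on it.

Three measured compounds share one core and differ only in the group on the saturated ring carbon. Compound 1 `Cc1nc(N2CCC(N3CCOC3=O)CC2)nc2ccc(NC(=O)/C=C/c3ccc(OC(F)(F)F)cc3)cc12` gives 41 nM in an assay on CHO-K1 cells for displacement of a labelled ligand from melanin-concentrating hormone receptor 1 (Homo sapiens), read by scintillation proximity assay, with a stated time of 2 h; a higher number here means a weaker inhibitor, a lower number a stronger inhibitor. Compound 2 `COCC(=O)NC1CCN(c2nc(C)c3cc(NC(=O)/C=C/c4ccc(OC(F)(F)F)cc4)ccc3n2)CC1` gives 32 nM in this assay, and compound 3 `Cc1nc(N2CCC(N3CCNC3=O)CC2)nc2ccc(NC(=O)/C=C/c3ccc(OC(F)(F)F)cc3)cc12` gives 66 nM in this assay. The steps are a 1.3-fold lower number from compound 1 to compound 2 (0.11 log units; within the scatter), a 1.6-fold higher number from compound 1 to compound 3 (0.21 log units; within the scatter) and a 2.1-fold higher number from compound 2 to compound 3 (0.31 log units; beyond the scatter). Compound 3 therefore has the highest number of the three, though only its gap to compound 2 exceeds the scatter.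

Compound 4 `Cc1nc(NCCCNS(C)(=O)=O)nc2ccc(NC(=O)/C=C/c3ccc(OC(F)(F)F)cc3)cc12` differs from compound 3 by (3-(methanesulfonamido)propyl)amino in place of 4-(2-oxoimidazolidin-1-yl)piperidin-1-yl on an aromatic carbon. Among the measured compounds shown here, none of the measured steps touches this change: all three vary only the substituent on the saturated ring carbon, and all are small. For the measured compounds named here, removing both rings is a larger change than any measured, so no step bears on it directly and the expectation is wide. Compound 4 is expected to give a higher number, the expected step being a 2.3-fold higher number from compound 3 to compound 4 (0.36 log units; beyond the scatter). The estimate for compound 4 in this assay is 150 nM, with a range from 40 nM to 600 nM.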

Compound 4, half-maximal inhibitory concentration: 54 nM
The estimate for compound 4 lay 2.8-fold (0.44 log units) above the measured number; the measured number falls inside the stated range.
By their numbers in this assay, from the lowest: compounds 2, 1, 4 and 3 (each within the scatter of the next, the first and the last beyond it).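

In this assay, the ring-free (3-(methanesulfonamido)propyl)amino chain on this aromatic carbon, between two ring nitrogen atoms, shows a 1.2-fold lower number from compound 3 to compound 4 (0.09 log units; within the scatter) and a 1.7-fold higher number from compound 2 to compound 4 (0.23 log units; within the scatter) and also a 1.3-fold higher number from compound 1 to compound 4 (0.12 log units; within the scatter), all within the scatter. The six-membered non-aromatic ring of compounds 1, 2 and 3 is therefore not required at this position for a number in this range, at least with this one chain as the replacement. Nothing available explains why the chain holds up so well.

The ring, the linker and the end group all change at once in compound 4, so the part of the chain that matters remains unresolved. A shorter or longer chain, or a terminal amine or carboxylic acid in place of the methanesulfonamido group, would begin to separate chain length from end group.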